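Swapping a nitrile-bearing ring for a methoxy-bearing ring

The source may report more compounds than this note shows. Statements on the series, on what has been measured and on what is new or still open speak of the compounds shown alone.

Compound 1, `COc1ccc(C)cc1NC(=S)N/N=C/c1ccc2ccccc2n1`, gives in a functional assay on HT-29 cells (Homo sapiens) for antiproliferative activity, read by sulforhodamine B assay, with a stated time of 72 h (on this read-out higher numbers stand for weaker inhibition and lower numbers for stronger inhibition), only the limit > 100000 nM.
Compound 2, `N#Cc1ccc(NC(=S)N/N=C/c2ccc3ccccc3n2)cc1`, gives in this assay 15600 nM.
Compound 3, `NC(=S)N/N=C/c1ccc2cccnc2n1`, gives in this assay 12800 nM.

Among the two values that are numbers, compound 2 has the higher one, but compound 3 sits so close that the two cannot be told apart within the usual scatter. Compound 1 stands apart only in that it reached (the limit of > 100000 nM in this assay, at which 1 of the 3 values shown sits), so no number is known for it.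

The next compound, compound 4, `COc1cccc(NC(=S)N/N=C/c2ccc3ccccc3n2)c1`, is reached from compound 2 by one change: 3-methoxyphenyl in place of 4-cyanophenyl on an amide-type nitrogen. In words, 3-methoxyphenyl in place of 4-cyanophenyl on an amide-type nitrogen. Among the measured compounds shown here, no measured pair in this set makes exactly that change, so the size of the step has to be judged from what the three measured compounds show. Compound 1, which also carries a methoxy group on the ring attached to that nitrogen, gave only a limit, while compound 2 with the nitrile gave a number. The step from compound 2 to compound 4 is therefore expected to run toward weaker inhibition, estimated as a 2.6-fold higher number from compound 2 to compound 4 (0.41 log units; beyond the scatter), with a fair chance that compound 4 also reports only a limit. Compound 4 is expected to give about 40000 nM, within a range of 12000 nM to 130000 nM.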

Compound 4, half-maximal inhibitory concentration: 82400 nM
The estimate for compound 4 lay 2.1-fold (0.31 log units) below the measured number; the measured number falls inside the stated range.
By their numbers in this assay, from the lowest: compounds 3 and 2 (each within the scatter of the next); then compound 4. At a limit, above all of these: compound 1.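

Putting 3-methoxyphenyl in place of 4-cyanophenyl on an amide-type nitrogen gives, in this assay, a 5.3-fold higher number from compound 2 to compound 4 (0.72 log units; beyond the scatter), which means weaker inhibition. Among the compounds shown here, this is the first step in the set that can be read at this position, and it shows that the group on that nitrogen can shift the read-out beyond the scatter even when the counts stay the same: both groups have 8 heavy atoms, one six-membered aromatic ring and 1 hydrogen-bond acceptor. A methoxy-bearing ring on that nitrogen also need not end at a limit, since compound 4 gives a number, and compound 1 alone remains at one: the limit of > 100000 nM in this assay, at which 1 of the 4 values shown sits.

This single step exchanges a nitrile for a methoxy group and also changes where the substituent sits on the ring, so the compounds shown cannot separate the effect of the group from the effect of its location. Going by these compounds, it also remains open how an amine, a carboxylic acid or a longer chain on that ring would read out in this assay.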